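The compounds below may be only part of what the source reports. "The series", "measured", "known", "first", "only" and "open" are said of these compounds alone.

Measured so far in a functional assay on HEK293 cells for agonist activity at growth hormone secretagogue receptor type 1 (Homo sapiens), read by HTRF and inositol phosphate accumulation, with a stated time of 90 min, in the presence of a further agent that is not named here; on this read-out higher numbers stand for larger maximal responses and lower numbers for smaller maximal responses:
- compound 1, `Cc1ccc2[nH]c(C(=O)N[C@H]3CN(S(=O)(=O)c4ccnc(C)c4)C[C@@H]3C(=O)NCCN(C)C)cc2c1`: 91%
- compound 2, `Cc1ccc2[nH]c(C(=O)N[C@H]3CCN(S(=O)(=O)N4CCOCC4)C[C@@H]3C(=O)NCCN(C)C)cc2c1`: 98%
- compound 3, `Cc1csc(C(=O)N[C@H]2CN(S(=O)(=O)c3ccccc3)C[C@@H]2C(=O)N[C@H]2CCCNC2)n1`: 63%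

Compound 3 has the lowest of the three numbers in this assay. The nearest is compound 1, higher by a margin beyond the scatter; the furthest is compound 2, higher by a larger margin, also beyond the scatter. Compounds 1 and 2 differ from compound 3 in several places at once, so no single change can be read from them.

Compound 4, `O=C(N[C@H]1CN(S(=O)(=O)c2ccccc2)C[C@@H]1C(=O)N[C@H]1CCCNC1)c1nnc(-c2ccc(F)cc2)s1`, differs from compound 3 as follows: a group of 12 heavy atoms (8 carbon, 2 nitrogen, 1 fluorine, 1 sulfur; one five-membered aromatic ring with 3 hetero atoms, one six-membered aromatic ring of carbon only) in place of a group of 6 heavy atoms (4 carbon, 1 nitrogen, 1 sulfur; one five-membered aromatic ring with 2 hetero atoms), on a carbonyl carbon. Going by the values given here, no measured pair shows this change. The step of a number 9 percentage points higher from compound 3 to compound 4 (within the scatter) is expected to be small and upward, possibly no larger than the scatter. Compound 4 is estimated at 72%, within 50% to 95%.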

Compound 4, largest response reached (Emax), in percent of the reference or control that the assay uses: 89%
Beside the measured number, compound 4's estimate is 17 percentage points below it, and the stated range covers the measured number.
By their numbers in this assay, from the lowest: compound 3; then compounds 4, 1 and 2 (each within the scatter of the next).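

In this assay, the group of 12 heavy atoms on the carbonyl carbon, in place of 4-methyl-1,3-thiazol-2-yl, gives a number 26 percentage points higher from compound 3 to compound 4 (beyond the scatter). This is the only change in one place shown so far, and it shows that this position accepts the larger group with a gain in maximal response. No available evidence accounts for the gain.

From the compounds shown here alone, the fluorine, the six-membered ring and the change of five-membered ring enter together, so their separate shares remain open. Also open, going by these compounds, is how a carboxylic acid or an amine in place of the fluorine would read.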